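Benzyloxy on compound 3: an antiproliferative estimate

A few compounds are considered here, and "the series" means these few. Any claim that something is new, unique, unknown or untested is made for them only; others in the source may bear on it.

Measured in a functional assay on SGC-7901 cells (Homo sapiens) for antiproliferative activity, read by MTT assay, with a stated time of 72 h; a higher number here means a weaker inhibitor, a lower number a stronger inhibitor:
Compound 1 `CCOC(=O)c1cc(-c2cc(OC)c(OC)c(OC)c2)c(-c2ccc(OC)cc2)s1`: 9760 nM
Compound 2 `COc1ccc(-c2sc(C(=O)O)cc2-c2cc(OC)c(OC)c(OC)c2)cc1OCc1ccccc1`: > 100000 nM (a limit of the assay, not a number)
Compound 3 `COc1ccc(-c2sccc2-c2cc(OC)c(OC)c(OC)c2)cc1`: 5470 nM

For the measured compounds named here, compound 3, at 5470 nM, has only one numeric neighbour. The comparison with it is a 1.8-fold lower number from compound 1 to compound 3 (0.25 log units; within the scatter). Compound 4 `COc1ccc(-c2sccc2-c2cc(OC)c(OC)c(OC)c2)cc1OCc1ccccc1` is built from compound 3 by a single change, benzyloxy in place of hydrogen on an aromatic carbon.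

Going by the values given here, no measured step makes this change alone. Among the compounds with values here, the one measured step, a 1.8-fold lower number from compound 1 to compound 3 (0.25 log units; within the scatter), concerns ethoxycarbonyl and not benzyloxy, so it says little here. Compound 2 carries the same benzyloxy together with a carboxylic acid, and it stands at the limit of > 100000 nM in this assay, at which 1 of the 3 values shown sits. Compound 2 differs from compound 3 in two places, so its limit cannot be assigned to benzyloxy alone.

A modest rise in the number in this assay is therefore expected, with wide uncertainty. The expected step is a 2.7-fold higher number from compound 3 to compound 4 (0.44 log units; beyond the scatter). Compound 4 is estimated at 15000 nM, with an expected range of 3000 nM to 70000 nM.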

Compound 4, half-maximal inhibitory concentration: > 100000 nM
Compound 4 was reported as a limit (the forecaster's own chance of this, stated with the estimate: 20%); middle value at least 6.6-fold (0.82 log units) away from the limit.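

In this assay, benzyloxy on this aromatic carbon, ortho to a methoxy group, can now be read on its own, and the change gives an at least 18-fold higher number from compound 3 to compound 4 (1.26 log units; beyond the scatter). Compound 2 had carried benzyloxy only together with a carboxylic acid, whereas compound 4 has no carboxy group and is still reported as a limit, so the carboxylic acid is not needed for a result at that limit. The step between compound 2 and compound 4 cannot be read, and the two compounds share the same limit: the limit of > 100000 nM in this assay, at which 2 of the 4 values shown sit.

The compounds shown leave open whether a smaller group at this place, such as hydroxy or ethoxy, would stay close to compound 3. They also leave open whether an amine on the added benzene ring would change the outcome.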